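The source may hold more compounds than are shown below. What is called first, only, known or untested is meant among the compounds shown, and "the series" means these compounds.

The compounds measured in a functional assay on HCT-116 cells (Homo sapiens) for cytotoxicity, read by MTT assay, with a stated time of 72 h (on this read-out lower numbers stand for stronger inhibition and higher numbers for weaker inhibition), are these.
Compound 1 `N[C@H]1CC[C@H](Nc2c(C(=O)NCc3ccc(F)cc3)nc(N3CCCCS3(=O)=O)c3cccnc23)CC1` gives > 10000 nM, which is a limit of the assay.
Compound 2 `CC(C)(C)OC(=O)N1CCN(c2c(C(=O)NCc3ccc(F)cc3)nc(Br)c3cccnc23)CC1` gives > 10000 nM, again a limit of the assay.
Compound 3 `Nc1ccc(Nc2c(C(=O)NCc3ccc(F)cc3)nc(Br)c3cccnc23)cc1` gives 10000 nM.

Among the measured compounds shown here, compound 3 thus stands as the only compound with a number in this assay; the other two values sit at the limit of > 10000 nM in this assay, at which 2 of the 3 values shown sit. The compound not yet measured is compound 4 `O=C(NCc1ccc(F)cc1)c1nc(Br)c2cccnc2c1NCc1ccccc1`. Its difference from compound 3 is benzyl in place of 4-aminophenyl on a nitrogen on an aromatic ring. For the measured compounds named here, no measured pair shows this change, so the step from compound 3 to compound 4 cannot be read from a neighbour. With every value shown at or beyond the same ceiling, the account expects no movement beyond the usual scatter, a step of no change at the digits printed from compound 3 to compound 4 (within the scatter). Compound 4 is therefore estimated at 10000 nM in this assay, with a range from 4000 nM to 30000 nM.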

Compound 4, half-maximal inhibitory concentration: > 20000 nM
Compound 4: no number, only a limit; the forecaster's own chance of this, stated with the estimate: 55%; middle value at least 2.0-fold (0.30 log units) away from the limit.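

In this assay, benzyl in place of 4-aminophenyl on this nitrogen gives an at least 2.0-fold higher number from compound 3 to compound 4 (0.30 log units; that floor lies within the scatter), so this change shows no sign of stronger inhibition. Compound 4 gives > 20000 nM, which is a limit of the assay. Among the compounds shown here, this is the only measured pair that differs at this nitrogen, and with one end a limit, the full size of its step cannot be read.

The compounds shown leave open whether a longer chain such as 2-phenylethyl, or 4-carboxyphenyl, on this nitrogen would give stronger inhibition than compound 3 does.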